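Moving one hydroxyl on the shared core

The source may hold more compounds than are shown below. What is called first, only, known or untested is meant among the compounds shown, and "the series" means these compounds.

For the measured compounds named here, compound 2 `Oc1ccc(-c2cc(-c3cccc(O)c3)cc(-c3cccc(O)c3)n2)cc1` gives 1560 nM in an ADME assay on HEK293 cells (Homo sapiens) for cytotoxicity, read by CCK-8 assay, with a stated time of 4 days (a lower number here means a stronger inhibitor, a higher number a weaker inhibitor), the highest of the three numbers so far. Compound 1 `Oc1ccc(-c2cc(-c3ccc(O)cc3)nc(-c3ccc(O)cc3)c2)cc1` gives 790 nM in this assay, within the scatter of compound 2. Going by the values given here, compound 3 `Oc1cccc(-c2cc(-c3cccc(O)c3)nc(-c3cccc(O)c3)c2)c1` gives 740 nM in this assay; the step of a 2.1-fold lower number from compound 2 to compound 3 (0.32 log units; beyond the scatter) is the only measured step and is modest. Compound 4 `Oc1ccc(-c2cc(-c3cccc(O)c3)cc(-c3ccccc3O)n2)cc1` differs from compound 2 by 2-hydroxyphenyl in place of 3-hydroxyphenyl on an aromatic carbon. Among the compounds with values here, no measured pair shows 2-hydroxyphenyl entering, so the step from compound 2 to compound 3 bears on it only loosely: exchanging 4-hydroxyphenyl for 3-hydroxyphenyl shifted the number modestly at most. For compound 4 a step of a 1.2-fold lower number from compound 2 to compound 4 (0.08 log units; within the scatter) of at most modest size is expected, direction uncertain. The estimate for compound 4 is 1300 nM, range 500 nM to 3500 nM.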

Compound 4, half-maximal inhibitory concentration: > 50000 nM
Compound 4: no number, only a limit; the forecaster's own chance of this, stated with the estimate: 5%; middle value at least 38-fold (1.58 log units) away from the limit.
By their numbers in this assay, from the lowest: compounds 3, 1 and 2 (each within the scatter of the next, the first and the last beyond it). At a limit, above all of these: compound 4.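

Here, on the aromatic carbon next to the ring nitrogen, 2-hydroxyphenyl in place of 3-hydroxyphenyl gives an at least 32-fold higher number from compound 2 to compound 4 (1.50 log units; beyond the scatter). The two compounds have the same atoms, so this position responds strongly to where the hydroxyl sits on the attached ring, which the earlier step, a 2.1-fold lower number from compound 2 to compound 3 (0.32 log units; beyond the scatter), gave no hint of. Compound 4 reads only as a limit, not a number: the limit of > 50000 nM in this assay, at which 1 of the 4 values shown sits.

As far as these compounds go, whether a 2-methoxyphenyl or 2-aminophenyl group at this position would behave the same stays open. So does the effect of 2-hydroxyphenyl elsewhere on the shared core.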